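One double bond, drawn the other way

The source may hold more compounds than are shown below. What is called first, only, known or untested is meant among the compounds shown, and "the series" means these compounds.

In a functional assay on HT-29 cells (Homo sapiens) for inhibition (on this read-out lower numbers stand for stronger inhibition and higher numbers for weaker inhibition), compound 1 `Cc1ccc(/C=C\c2ccc3ccccc3c2)cc1` gives > 5000 nM, which is a limit of the assay and not a number. Within the data shown here, compound 2 `CN(C)c1ccc(/C=C/c2ccc3ccccc3c2)cc1` gives 3660 nM, the only actual number so far. Compound 3 `CN(C)c1ccc(/C=C\c2ccc3ccccc3c2)cc1` has not been measured. Set against compound 2, its change is the two compounds have the same atoms and bonds and differ only in configuration as drawn: 1 of 1 stereo elements differ; a double bond is drawn E in compound 2 and Z in compound 3: a double bond is drawn E in compound 2 and Z in compound 3. Among the measured compounds shown here, no measured pair shows what this change does, so the expectation is loose. A modest gain in inhibition is expected, with an estimated 2.4-fold lower number from compound 2 to compound 3 (0.39 log units; beyond the scatter). The estimate for compound 3 is 1500 nM, with an expected range from 250 nM to 6000 nM.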

Compound 3, half-maximal inhibitory concentration: 3660 nM
For compound 3 the middle estimate is 2.4-fold (0.39 log units) below the measured one; measured number inside the range.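

Drawing the double bond Z rather than E gives no change at the digits printed from compound 2 to compound 3 (within the scatter) in this assay, so with dimethylamino on the ring, this configuration leaves the read-out unmoved. Dimethylamino in place of methyl gives an at least 1.3-fold lower number from compound 1 to compound 3 (0.13 log units; that floor lies within the scatter). That step is only a floor, since compound 1 stands at a limit and not a number: the limit of > 5000 nM in this assay, at which 1 of the 3 values shown sits.

Going by these compounds, it remains open whether the double bond's configuration would matter as little with methyl on the ring, and whether a carboxylic acid or a primary amine in place of dimethylamino would shift the read-out beyond the scatter.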